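This account rests on a few compounds, and the source may have more. Where it says the series, first, only, none or still open, it means among the compounds named here.

In a functional assay on HCT-116 cells (Homo sapiens) for inhibition, read by MTT assay, with a stated time of 72 h (on this read-out lower numbers stand for stronger inhibition and higher numbers for weaker inhibition), three compounds have been measured so far:

compound 1, `O=C1Nc2cccc(Br)c2/C1=N/NC(=S)N1CCN(c2ccccc2)CC1`, gives 33600 nM
compound 2, `O=C1Nc2cccc(Cl)c2/C1=N/NC(=S)N1CCN(c2ccccc2)CC1`, gives 42100 nM
compound 3, `O=C1Nc2cc(Br)ccc2/C1=N/NC(=S)N1CCN(c2ccccc2)CC1`, gives 14500 nM

Compound 1 and compound 2 share one core, while compound 3 is built from the same atoms joined differently; the difference between the two cores is not broken down here. The change from compound 1 to compound 2 is chloro in place of bromo on an aromatic carbon, and it gave a 1.3-fold higher number from compound 1 to compound 2 (0.10 log units; within the scatter).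

Compound 4, `O=C1Nc2cc(Cl)ccc2/C1=N/NC(=S)N1CCN(c2ccccc2)CC1`, has not yet been measured. It is made from compound 3 by chloro in place of bromo on an aromatic carbon. This is the same kind of change as that from compound 1 to compound 2, though not the same: in compound 1 the group sits ortho to a fused ring and meta to a fused ring, whereas in compound 3 it sits meta to a fused ring and para to a fused ring. The step from compound 3 to compound 4 is expected to be about a 1.2-fold higher number from compound 3 to compound 4 (0.09 log units; within the scatter), because a 1.3-fold higher number from compound 1 to compound 2 (0.10 log units; within the scatter) stayed within the scatter. Compound 4 is therefore estimated at 18000 nM, with a likely range from 9000 nM to 40000 nM.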

Compound 4, half-maximal inhibitory concentration: 17900 nM
Compound 4: the middle estimate sits 1.0-fold (0.00 log units) above what was measured, within the range that was stated.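

In this assay, chloro in place of bromo on an aromatic carbon gave a 1.2-fold higher number from compound 3 to compound 4 (0.09 log units; within the scatter), and the swap reads alike on the two cores: the same change on two cores in this assay, a 1.3-fold higher number (0.10 log units; within the scatter) from compound 1 to compound 2 and a 1.2-fold higher number (0.09 log units; within the scatter) from compound 3 to compound 4, 1.0-fold (0.01 log units) apart, within the scatter of two such steps. Within these two pairs, then, what was seen on one core also held on the other. This does not show that the swap would behave this way on any further core, that other changes would carry over as well, or why bromo and chloro read alike here.

On these data alone, whether a quite different group at this place, such as a fluoro, a methoxy or an amine, would also leave the number within the scatter remains open.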